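Fluoro in Place of Chloro: What to Expect of Compound 4

The compounds below may be only part of what the source reports. "The series", "measured", "known", "first", "only" and "open" are said of these compounds alone.

In a functional assay on RAW264.7 cells (Mus musculus) for inhibition (a higher number here means a weaker inhibitor, a lower number a stronger inhibitor), compound 1 `CCOC(=O)C1=CCCCC1S(=O)(=O)Nc1ccc(Cl)cc1F` gives 160 nM. This is the middle of three numbers: compound 2 `CCOC(=O)C1=CCCCC1S(=O)(=O)Nc1ccccc1Cl` gives 12 nM, and compound 3 `CCOC(=O)C1=CCCCC1S(=O)(=O)Nc1ccc(Cl)cc1` gives 400 nM.

Compound 4 `CCOC(=O)C1=CCCCC1S(=O)(=O)Nc1ccc(F)cc1F` has not yet been measured. It keeps the core of compound 1 and makes a single swap: fluoro in place of chloro on an aromatic carbon.

Among the measured compounds shown here, no measured step makes this exact swap, so the evidence is indirect. Putting hydrogen in place of fluoro on an aromatic carbon gives a 2.5-fold higher number from compound 1 to compound 3 (0.40 log units; beyond the scatter), a modest step. This shows that one small substitution can move the number beyond the scatter. Putting 4-chlorophenyl in place of 2-chlorophenyl gives a 33-fold higher number from compound 2 to compound 3 (1.52 log units; beyond the scatter), a large step. Between these two compounds, the place of the chloro matters greatly, but that step moves the chloro rather than replacing it. Compound 1 and compound 3 both carry the chloro that compound 4 loses, and both have higher numbers than compound 2, which lacks it at that place.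

A modest move toward a lower number is therefore expected, shown as the estimated 2.3-fold lower number from compound 1 to compound 4 (0.36 log units; beyond the scatter) in this assay. For compound 4 the estimated value is 70 nM, with an expected range of 20 nM to 250 nM.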

Compound 4, half-maximal inhibitory concentration: 16 nM
For compound 4 the middle estimate is 4.4-fold (0.64 log units) above the measured one; measured number below the stated range.
By their numbers in this assay, from the lowest: compounds 2 and 4 (each within the scatter of the next); then compound 1; then compound 3.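

In this assay, fluoro in place of chloro on the aromatic carbon para to a large group gives a 10-fold lower number from compound 1 to compound 4 (1.00 log units; beyond the scatter), so the identity of the halogen at this place matters and not only its presence. The earlier steps shown here removed the fluoro or moved the chloro, but none replaced the chloro here with another group. This swap exchanges a single heavy atom for a single heavy atom, with no ring, hydrogen-bond donor, hydrogen-bond acceptor or net charge entering or leaving, and nothing measured among these data accounts for a step of this size.

The compounds shown leave open how other groups would behave at this place, such as a methyl, a methoxy, a nitrile or an amine, and how plain hydrogen here would compare once the other fluoro is kept. They also leave open whether the same swap would give a similar step on a ring without that other fluoro, or with a methyl ester in place of the ethyl ester of the shared core.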